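Methoxy for methyl on the aniline ring: solubility outlook

The source may hold more compounds than are shown below. What is called first, only, known or untested is meant among the compounds shown, and "the series" means these compounds.

Measured so far:
compound 1, `C=CC(=O)N1CC[C@H](N2C(=O)N(c3ccccc3)Cc3cnc(Nc4ccc(N5CCN(C)CC5)cc4)nc32)C1`: 976 ug/mL
compound 2, `C=CC(=O)N1CC[C@H](N2C(=O)N(c3ccccc3)Cc3cnc(Nc4ccc(N5CCN(C)CC5)c(C)c4)nc32)C1`: 1270 ug/mL

Of the compounds shown here, two share the same core and have been measured in a physicochemical assay for solubility, read by HPLC, in phosphate buffer, measured as thermodynamic solubility, with a stated time of 24 h, at pH 6.8; on this read-out lower numbers stand for lower solubility and higher numbers for higher solubility. Compound 1, with hydrogen on the aromatic carbon in question, gives 976 ug/mL. Compound 2 carries a methyl there and gives 1270 ug/mL. Among the compounds with values here, the only measured step, a 1.3-fold higher number from compound 1 to compound 2 (0.11 log units; within the scatter), therefore lies within the scatter, so compound 2 and compound 1 cannot be told apart on this read-out; compound 2 merely shows the larger of the two numbers.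

Compound 3, `C=CC(=O)N1CC[C@H](N2C(=O)N(c3ccccc3)Cc3cnc(Nc4ccc(N5CCN(C)CC5)c(OC)c4)nc32)C1`, is the next member. It differs from compound 2 in one place: methoxy in place of methyl on an aromatic carbon. Within the data shown here, no measured step exchanges methyl for methoxy, so the only guidance is the step from hydrogen to methyl, which was small. With one more heavy atom and one hydrogen-bond acceptor entering at a position that already tolerated a methyl without a change beyond the scatter, no step beyond the scatter is expected in this assay, and the expected step of a 1.0-fold higher number from compound 2 to compound 3 (0.01 log units; within the scatter) reflects that. Compound 3 is accordingly estimated at 1300 ug/mL, within a range from 650 ug/mL to 2600 ug/mL.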

Compound 3, solubility: 256 ug/mL
The estimate for compound 3 lay 5.1-fold (0.71 log units) above the measured number; measured number outside the range, below it.
By their numbers in this assay, from the lowest: compound 3; then compounds 1 and 2 (each within the scatter of the next).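

In this assay, the aromatic carbon ortho to a 4-methylpiperazin-1-yl group looked indifferent while it held only hydrogen or methyl, but it proves sensitive to what is placed there: methoxy in place of methyl gives a 5.0-fold lower number from compound 2 to compound 3 (0.70 log units; beyond the scatter), and methoxy in place of hydrogen gives a 3.8-fold lower number from compound 1 to compound 3 (0.58 log units; beyond the scatter). This position therefore does not treat all small groups alike, since hydrogen and methyl cannot be told apart on this read-out, while methoxy stands apart from both. Nothing available explains the drop, so the numbers record what happened without giving a cause for it.

The compounds shown leave open whether the drop follows from the oxygen atom or from the length of the group, a question that an ethyl group on the same carbon would help to answer. Also open, from the compounds shown here alone, is how a hydroxyl group or a longer ethoxy group would behave at this position, and whether the same exchange of methyl for methoxy would give a similar step on a different core.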